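The source may report more compounds than this note shows. Statements on the series, on what has been measured and on what is new or still open speak of the compounds shown alone.

- compound 1 `O=C1CS/C(=N/Nc2nncc3ccccc23)N1c1ccccc1`: 57 nM
- compound 2 `CCN1C(=O)CS/C1=N/Nc1nncc2ccccc12`: 76 nM

Going by the values given here, in a functional assay on K562 cells (Homo sapiens) for antiproliferative activity, read by sulforhodamine B assay, with a stated time of 72 h (on this read-out higher numbers stand for weaker inhibition and lower numbers for stronger inhibition), compound 2 gives 76 nM and stands within the scatter of compound 1, the only other measured compound, with a 1.3-fold higher number from compound 1 to compound 2 (0.12 log units; within the scatter). Compound 3 `O=C1CS/C(=N/Nc2nncc3ccccc23)N1` is the next case: hydrogen in place of ethyl on an amide-type nitrogen in a ring. Among the compounds with values here, one measured step bears on this, the exchange at that same nitrogen, and it stayed small: a 1.3-fold higher number from compound 1 to compound 2 (0.12 log units; within the scatter). Within the data shown here, no measured compound carries hydrogen there, so this is an extrapolation and the range is kept wide. A step beyond the scatter is not expected, with a slight drift toward a higher number as the only lean. The estimated step is a 1.4-fold higher number from compound 2 to compound 3 (0.16 log units; within the scatter). For compound 3 the expected value is 110 nM, with an estimated range of 35 nM to 350 nM.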

Compound 3, half-maximal inhibitory concentration: 85 nM
Estimate against measurement, compound 3: 1.3-fold (0.11 log units) above, within the range that was stated.
By their numbers in this assay, from the lowest: compounds 1, 2 and 3 (each within the scatter of the next).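

In this assay, hydrogen on the amide-type nitrogen in the ring, with no heavy atom there, stands within the scatter of both ethyl and phenyl, with a 1.1-fold higher number from compound 2 to compound 3 (0.05 log units; within the scatter) and a 1.5-fold higher number from compound 1 to compound 3 (0.17 log units; within the scatter). Going by these compounds alone, the earlier pair compared only two carbon groups at this nitrogen; compound 3 shows that values of this size do not depend on having a carbon substituent there. Nothing available explains why this read-out is so flat across hydrogen, ethyl and phenyl.

As far as these compounds go, whether this tolerance extends to a longer chain, an amine or a carboxylic acid at the same nitrogen stays open. From the compounds shown here alone, what a change elsewhere on the shared core would do also stays open.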